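Isobutyl Ester on the Thiophene Core: An Expected Step

The compounds below may be only part of what the source reports. "The series", "measured", "known", "first", "only" and "open" are said of these compounds alone.

Measured so far:
compound 1 `CCCOC(=O)C1=C(C)N(C)C(=O)NC1c1ccco1`: 23%
compound 2 `CC1=C(C(=O)OCC(C)C)C(c2ccco2)NC(=O)N1C`: 4%
compound 3 `CCCOC(=O)C1=C(C)N(C)C(=O)NC1c1ccsc1`: 1%

These values come from an assay on membranes from HEK293 cells for displacement of a labelled ligand from adenosine receptor A2b (Homo sapiens), read by scintillation counting, with a stated time of 30 min, tested at 1 uM; on this read-out higher numbers stand for more inhibition at the one concentration tested (going by the name of the read-out) and lower numbers for less inhibition. Compound 1 and compound 2 differ by methyl in place of hydrogen on a saturated chain carbon bound to two saturated chain carbons, and this gave a number 19 percentage points lower from compound 1 to compound 2 (beyond the scatter). The two cores differ by thiophen-3-yl in place of furan-2-yl on a saturated ring carbon, which gave a number 22 percentage points lower from compound 1 to compound 3 (beyond the scatter). Compound 3 therefore stands lowest of the three, though its value sits within the scatter of compound 2.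

Compound 4 `CC1=C(C(=O)OCC(C)C)C(c2ccsc2)NC(=O)N1C` carries the same change on the core of compound 3: methyl in place of hydrogen on a saturated chain carbon bound to two saturated chain carbons. Compound 3 already gives a value near the bottom of this read-out, namely 1%, so little room remains for a further decrease. Compound 4 is therefore expected to show no change at the digits printed from compound 3 to compound 4 (within the scatter), a smaller step than the earlier one. Compound 4 is thus estimated at 1%, between -8% and 9%.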

Compound 4, a percentage reported as inhibition, at one concentration (the size of the read-out at that concentration, not a potency): 1%
The estimate for compound 4 equals the measured number at the digits printed; the measured number falls inside the stated range.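

In this assay, the change from propyl to isobutyl on the core of compound 3 gave no change at the digits printed from compound 3 to compound 4 (within the scatter), so it did not carry over at the size seen on the core of compound 1: the same change on two cores in this assay, a number 19 percentage points lower (beyond the scatter) from compound 1 to compound 2 and no change at the digits printed (within the scatter) from compound 3 to compound 4, 19 percentage points apart, beyond the scatter of two such steps Thiophen-3-yl in place of furan-2-yl likewise gave a number 3 percentage points lower from compound 2 to compound 4 (within the scatter), and this step also differs from its earlier counterpart: the same change on two cores in this assay, a number 22 percentage points lower (beyond the scatter) from compound 1 to compound 3 and a number 3 percentage points lower (within the scatter) from compound 2 to compound 4, 19 percentage points apart, beyond the scatter of two such steps This does not show that one change truly depends on the other: compound 3 already gives 1%, and a value that low leaves little room for any further drop.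

As far as these compounds go, it remains open whether a benzyl ester or an amine on the ester chain would raise the number on either core. From the compounds shown here alone, it also remains open how the propyl to isobutyl change behaves on a core that starts higher on this read-out.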